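From 3-Nitrophenyl to 4-Nitrophenyl on a Shared Core

A few compounds are considered here, and "the series" means these few. Any claim that something is new, unique, unknown or untested is made for them only; others in the source may bear on it.

For the measured compounds named here, in an assay on cells for activation of Cystic fibrosis transmembrane conductance regulator (Homo sapiens), read by fluorescence, with a stated time of 10 min (on this read-out higher numbers stand for an effect only at larger amounts of compound and lower numbers for an effect already at smaller amounts), compound 2 `O=c1c(-c2cccc([N+](=O)[O-])c2)nc2ccccc2n1Cc1ccccc1` gives 9 nM, the only plain number in this set. Compound 1 `O=C(O)c1ccc([N+](=O)[O-])c(-c2nc3ccccc3n(Cc3ccccc3)c2=O)c1` reaches only a limit of the assay, > 10000 nM, as noted in the limit of > 10000 nM in this assay, at which 1 of the 2 values shown sits. Compound 3 `O=c1c(-c2ccc([N+](=O)[O-])cc2)nc2ccccc2n1Cc1ccccc1` differs from compound 2 by 4-nitrophenyl in place of 3-nitrophenyl on an aromatic carbon. Going by the values given here, no step between two measured compounds is available, so the size of this change cannot be read from the data; a shift somewhat beyond the usual scatter, toward weaker effect, is expected rather than none. Compound 3 is expected to give 40 nM in this assay, within 8 nM to 300 nM. The step expected is a 4.4-fold higher number from compound 2 to compound 3 (0.65 log units; beyond the scatter).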

Compound 3, half-maximal effective concentration: 1000 nM
The estimate for compound 3 lay 25-fold (1.40 log units) below the measured number, outside the stated range (above it).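

In this assay, the change from 3-nitrophenyl to 4-nitrophenyl brings a 110-fold higher number from compound 2 to compound 3 (2.05 log units; beyond the scatter), although the two groups carry the same atoms and the same counts. For the compounds shown here, the aromatic carbon next to the ring nitrogen therefore tolerates these two isomeric groups very differently, which the earlier compounds could not show. Nothing measured here gives a reason for the size of this step. The compounds shown leave open whether the nitro group is needed at all, or whether an amine or a nitrile on the same phenyl ring would keep the effect.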